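Amine nitrogen substituents: working notes towards compound 4

The source may hold more compounds than are shown below. What is called first, only, known or untested is meant among the compounds shown, and "the series" means these compounds.

Values in a functional assay on MCF7 cells (Homo sapiens) for cytotoxicity, read by sulforhodamine B assay, with a stated time of 48 h; on this read-out higher numbers stand for weaker inhibition of growth and lower numbers for stronger inhibition of growth:
- compound 1 `Cc1nn(-c2ccccc2)c(Oc2ccc(-c3nc4cc([N+](=O)[O-])ccc4[nH]3)cc2)c1/C=N/Nc1ccccc1`: 12300 nM
- compound 2 `Cc1nn(-c2ccccc2)c(Oc2ccc(-c3nc4cc([N+](=O)[O-])ccc4[nH]3)cc2)c1/C=N/NC(N)=O`: 13800 nM
- compound 3 `Cc1nn(-c2ccccc2)c(Oc2ccc(-c3nc4cc([N+](=O)[O-])ccc4[nH]3)cc2)c1/C=N/NC(N)=S`: 9200 nM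

Compound 3 cannot be separated from the other two, since its value lies within the scatter of both. Within the data shown here, the steps that bear on the next change are a 1.3-fold lower number from compound 1 to compound 3 (0.13 log units; within the scatter), a 1.5-fold lower number from compound 2 to compound 3 (0.18 log units; within the scatter) and a 1.1-fold higher number from compound 1 to compound 2 (0.05 log units; within the scatter). All three swap the group on the amine nitrogen, and none leaves the scatter. Compound 4 `CC(=O)N/N=C/c1c(C)nn(-c2ccccc2)c1Oc1ccc(-c2nc3cc([N+](=O)[O-])ccc3[nH]2)cc1` brings acetyl to that nitrogen: a group of 3 heavy atoms (2 carbon, 1 oxygen; no ring) in place of a group of 3 heavy atoms (1 carbon, 1 nitrogen, 1 sulfur; no ring), on an amine nitrogen. Among the measured compounds shown here, no measured compound carries acetyl there, so this rests on the three steps alone. In this assay no step beyond the scatter is expected. The expected step is a 1.3-fold higher number from compound 3 to compound 4 (0.12 log units; within the scatter). For compound 4 the estimated value is 12000 nM, with an expected range of 6000 nM to 24000 nM.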

Compound 4, concentration for 50% growth inhibition: 8900 nM
For compound 4 the middle estimate is 1.3-fold (0.13 log units) above the measured one; low and high end bracket the measured number.
By their numbers in this assay, from the lowest: compounds 4, 3, 1 and 2 (each within the scatter of the next).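

In this assay, acetyl on the amine nitrogen does not separate from the thiourea-type group of compound 3 (a 1.0-fold lower number from compound 3 to compound 4 (0.01 log units; within the scatter)), from carbamoyl (a 1.6-fold lower number from compound 2 to compound 4 (0.19 log units; within the scatter)) or from phenyl (a 1.4-fold lower number from compound 1 to compound 4 (0.14 log units; within the scatter)). Across the four compounds, a group with 0 hydrogen-bond donors therefore falls within the scatter of groups that carry them, and methyl in place of amino on the carbonyl carbon also stays within it. No measurement bears on why these values coincide. As far as these compounds go, whether a longer chain on that carbonyl carbon, or a carboxylic acid on this nitrogen, would leave the scatter remains open.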